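The source may hold more compounds than are shown below. What is called first, only, known or untested is meant among the compounds shown, and "the series" means these compounds.

Compounds measured so far in an ADME assay on MT4 cells (Homo sapiens) for cytotoxicity, read by MTT assay; on this read-out higher numbers stand for lower toxicity in this test and lower numbers for higher toxicity in this test:

Compound 1 `N#Cc1ccc(Nc2nccc(SC3CCCCC3)n2)cc1` gives > 402000 nM, which is a limit of this assay rather than a number.
Compound 2 `Cc1cnc(Nc2ccc(C#N)cc2)nc1SC1CCCCC1` gives 33400 nM.
Compound 3 `Cc1cc(NC2CCCCC2)nc(Nc2ccc(C#N)cc2)n1` gives 340 nM.

Among the numbers shown, compound 3 stands lowest, and compound 2 sits far higher. For the measured compounds named here, the one measured step, an at least 12-fold lower number from compound 1 to compound 2 (1.08 log units; beyond the scatter), concerns a methyl group and does not match the change at hand. Compound 4 `Cc1cc(SC2CCCCC2)nc(Nc2ccc(C#N)cc2)n1` differs from compound 3 by cyclohexylsulfanyl in place of cyclohexylamino on an aromatic carbon. Going by the values given here, no measured step covers this swap; the only guide is that compound 2, which also carries a cyclohexylsulfanyl group, gives 33400 nM, far above compound 3. A large rise is therefore expected, a 59-fold higher number from compound 3 to compound 4 (1.77 log units; beyond the scatter), though with wide uncertainty. Compound 4 is estimated at 20000 nM, between 3000 nM and 150000 nM.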

Compound 4, half-maximal cytotoxic concentration: >= 192000 nM
Compound 4 gave a limit, no number (the forecaster's own chance of this, stated with the estimate: 15%); middle value at least 9.6-fold (0.98 log units) away from the limit.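

In this assay compound 4 gives >= 192000 nM, a limit and not a number. Cyclohexylsulfanyl in place of cyclohexylamino on this aromatic carbon gives an at least 560-fold higher number from compound 3 to compound 4 (2.75 log units; beyond the scatter), a large change between two groups that differ only in the sulfur or nitrogen atom attaching the ring of carbon to the core. The single atom at this position therefore matters greatly for toxicity in this test, although this rests on one pair. The step between compound 1 and compound 4 cannot be read, leaving the methyl group's role here open. Also open, on these data alone, is where cyclohexyloxy, with oxygen as the attaching atom, would fall.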